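This account rests on a few compounds, and the source may have more. Where it says the series, first, only, none or still open, it means among the compounds named here.

Compound 1 `COc1cc(C2=NN(C(C)=O)C(c3cccc(OC)c3OC)O2)cc(OC)c1OC` was examined in a functional assay on PC-3 cells (Homo sapiens) for antiproliferative activity, read by MTT assay, tested at 1 uM (a lower number here means a weaker effect, a higher number a stronger effect of the compound at the concentration tested), where compound 1 gives 35%. Going by the values given here, the only other measured compound, compound 2 `COc1cc(C(=O)N/N=C/c2ccc(C(F)(F)F)cc2)cc(OC)c1OC`, gives 59.9% in this assay, so compound 1 stands as the lower of the two numbers, and the gap between them is larger than the usual run-to-run scatter of this kind of test. Compound 2 is built differently from compound 1 in several places at once, so the two values say nothing about any single structural change.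

Compound 3 `COc1cc(C2=NN(C(C)=O)C(c3ccccc3F)O2)cc(OC)c1OC` is not yet measured. It differs from compound 1 in one place: 2-fluorophenyl in place of 2,3-dimethoxyphenyl on a saturated ring carbon. Among the compounds with values here, no measured pair in this set shows what such an exchange does, so the expectation rests on compound 1 alone. The step from compound 1 to compound 3 is expected to stay within the scatter, in either direction, as a number 3 percentage points higher from compound 1 to compound 3 (within the scatter). Compound 3 is therefore expected to give about 38% in this assay, most likely somewhere between 20% and 58%.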

Compound 3, a percentage reported as inhibition, at one concentration (the size of the read-out at that concentration, not a potency): 13.5%
The estimate for compound 3 lay 24.5 percentage points above the measured number; the measured number lies below the stated range.
By their numbers in this assay, from the lowest: compound 3; then compound 1; then compound 2.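

In this assay, replacing 2,3-dimethoxyphenyl with 2-fluorophenyl on the saturated ring carbon gives a number 21.5 percentage points lower from compound 1 to compound 3 (beyond the scatter). Going by these compounds alone, this is the first comparison here in which only one place changes, and it shows that the group at this position can alter the antiproliferative read-out at the tested concentration, with 2,3-dimethoxyphenyl giving the higher number of this one pair. No accompanying measurement bears on why the number falls, so this pair records the size and direction of the change but not its cause.

The exchange removes both methoxy groups and adds a fluorine in a single step, so these compounds leave open whether the fall follows from losing the methoxy groups, gaining the fluorine, or both together. An unsubstituted phenyl ring, or a phenyl ring carrying a single methoxy group or a chlorine, at the same ring carbon could help separate these possibilities and show whether the trend extends beyond this one pair.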